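A few compounds are considered here, and "the series" means these few. Any claim that something is new, unique, unknown or untested is made for them only; others in the source may bear on it.

Measured so far:
- compound 1 `COc1cc(OC)c(OC)cc1/C=C/C(=O)c1ccc(OC)c2c1OC(C)(C)C=C2`: in a functional assay on SW-620 cells (Homo sapiens) for antiproliferative activity, read by MTT assay, with a stated time of 24 h (a higher number here means a weaker inhibitor, a lower number a stronger inhibitor), compound 1 gives > 10000 nM, which is a limit of the assay and not a number.
- compound 2 `COc1ccc(C(=O)/C=C/c2ccc(Br)cc2)c2c1C=CC(C)(C)O2`: in this assay compound 2 gives > 10000 nM, again a limit of the assay.
- compound 3 `CCN(CC)c1ccc(/C=C/C(=O)c2ccc(OC)c3c2OC(C)(C)C=C3)cc1`: in this assay compound 3 gives 670 nM.

Compound 3 therefore stands alone with the only numerical result in this assay; the other two results are limits (the limit of > 10000 nM in this assay, at which 2 of the 3 values shown sit). Among the compounds with values here, the one measured step that changes a single group is an at least 14-fold lower number from compound 2 to compound 3 (1.17 log units; beyond the scatter), diethylamino in place of bromo on an aromatic carbon, and it is the step that takes the series from a limit to a number.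

Compound 4 `COc1ccc(C(=O)/C=C/c2ccc(C(F)(F)F)cc2)c2c1C=CC(C)(C)O2` differs from compound 3 by trifluoromethyl in place of diethylamino on an aromatic carbon. Within the data shown here, the change removes the diethylamino group that accompanies the sole numerical value, and puts in its place a group of the kind seen in compound 2, which sits at the limit (the limit of > 10000 nM in this assay, at which 2 of the 3 values shown sit). The measured step from compound 2 to compound 3 bears directly on this, and a step of similar size is expected in this assay, in the opposite direction: a large rise in the number, a 22-fold higher number from compound 3 to compound 4 (1.35 log units; beyond the scatter), with a fair chance that only a limit is reported. For compound 4 the estimate in this assay is 15000 nM, with a range from 3000 nM to 60000 nM.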

Compound 4, half-maximal inhibitory concentration: > 10000 nM
Compound 4 was reported as a limit; the forecaster's own chance of this, stated with the estimate: 60%; the middle value lies beyond the limit too.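

On the aromatic carbon para to a large group, diethylamino is now the only group among those shown that gives a number, and a second replacement confirms this: trifluoromethyl in its place gives an at least 14-fold higher number from compound 3 to compound 4 (1.17 log units; beyond the scatter) in this assay. In this assay, going by these compounds, compound 4 gives > 10000 nM, which is a limit of the assay and not a number, so the true size of this step stays unknown. The step between bromo and trifluoromethyl cannot be read, as compound 2 and compound 4 both stand as limits, and the results now collect at a single ceiling: the limit of > 10000 nM in this assay, at which 3 of the 4 values shown sit.

The compounds shown leave open whether the number depends on the nitrogen of diethylamino or on its two ethyl chains, a question that dimethylamino, a ring amine such as piperidine, or a plain alkyl chain at this place would address. They also leave open how far compound 2 and compound 4 lie from each other, and whether any group at this place gives a lower number than compound 3.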